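Two Aryl Groups Swapped at One Ring Carbon

A few compounds are considered here, and "the series" means these few. Any claim that something is new, unique, unknown or untested is made for them only; others in the source may bear on it.

Compound 2 `CC1(C)Cc2c(-c3ccncc3)c(-c3ccccn3)nn2C1` gives > 100000 nM in a functional assay on K562 cells (Homo sapiens) for cytotoxicity, with a stated time of 72 h; on this read-out higher numbers stand for weaker inhibition and lower numbers for stronger inhibition; this is a limit of the assay, not a number.
Compound 3 `COCC1c2c(-c3ccncc3)c(-c3cccc(C)n3)nn2CC1(C)C` gives > 100000 nM in this assay, likewise a limit.
Compound 1 `Cc1cccc(-c2nn3c(c2-c2ccncc2)C(C)C(C)(C)C3)c1C#N` gives 92000 nM in this assay.

Compound 2 stands at the limit of the assay, where two of the three values sit (the limit of > 100000 nM in this assay, at which 2 of the 3 values shown sit), so its true weakness cannot be read off. Going by the values given here, no step between measured compounds is available. Compound 4 `CC1(C)Cc2c(-c3ccncc3)c(-c3ccccc3C#N)nn2C1` differs from compound 2 by 2-cyanophenyl in place of pyridin-2-yl on an aromatic carbon. Compound 1 also carries a nitrile on a phenyl ring and reaches only 92000 nM, so in this assay no step beyond the scatter is expected. Compound 4 is estimated at 100000 nM, with a range from 40000 nM to 250000 nM. For compound 4 the expected step is a number no higher from compound 2 to compound 4 (the limit leaves the size open).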

Compound 4, half-maximal inhibitory concentration: > 100000 nM
Compound 4 gave a limit, no number (the forecaster's own chance of this, stated with the estimate: 60%); the middle value lies on the limit itself.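

Compound 2 and compound 4 both give only a limit, so no step can be read between them: the limit of > 100000 nM in this assay, at which 3 of the 4 values shown sit.

On these data alone, the true strength of each compound, and whether 2-cyanophenyl in place of pyridin-2-yl changes it at all, stays open.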